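Adding a Bromine to the Weakest Analogue

The source may report more compounds than this note shows. Statements on the series, on what has been measured and on what is new or still open speak of the compounds shown alone.

Compound 1, `COc1ccc(C2CC(c3ccccc3)=NN2C2=NC(=O)/C(=C3\C(=O)Nc4ccc(Br)cc43)S2)cc1`, gives 550 nM in a functional assay on cells (Melanoma cell, Homo sapiens) for cytotoxicity, read by sulforhodamine B assay, with a stated time of 48 h; a higher number here means a weaker inhibitor of growth, a lower number a stronger inhibitor of growth.
Compound 2, `COc1ccc(C2=NN(C3=NC(=O)/C(=C4\C(=O)Nc5ccc(Br)cc54)S3)C(c3ccc(OC)cc3)C2)cc1`, gives 410 nM.
Compound 3, `COc1ccc(C2CC(c3ccc4ccccc4c3)=NN2C2=NC(=O)/C(=C3\C(=O)Nc4ccccc43)S2)cc1`, gives 27000 nM.

Compound 3 stands at the highest number of the three, so it is the weakest growth inhibitor among them; its gap to compound 1 and its gap to compound 2 both lie beyond the scatter. Compound 4, `COc1ccc(C2CC(c3ccc4ccccc4c3)=NN2C2=NC(=O)/C(=C3\C(=O)Nc4ccc(Br)cc43)S2)cc1`, is compound 3 with a single change: bromo in place of hydrogen on an aromatic carbon. Among the compounds with values here, the only measured step between compounds that differ in one place is a 1.3-fold lower number from compound 1 to compound 2 (0.13 log units; within the scatter), and it concerns a methoxy, not a bromine, so it says little about the change at hand. Compounds 1 and 2 both carry that same bromine and give far lower numbers than compound 3. Within the data shown here, each of them, however, also differs from compound 3 elsewhere, so no measured step shows the bromine change on its own. Among the measured compounds shown here, with no direct precedent, only a cautious expectation is possible: the bromine may lower the number to some degree, but a step beyond the scatter is not assured. Compound 4 is therefore estimated at 9000 nM, within a range from 2000 nM to 30000 nM, which corresponds to an expected step of a 3.0-fold lower number from compound 3 to compound 4 (0.48 log units; beyond the scatter).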

Compound 4, concentration for total growth inhibition: 190 nM
The estimate for compound 4 lay 47-fold (1.68 log units) above the measured number, and the stated range ends above it.
By their numbers in this assay, from the lowest: compound 4; then compounds 2 and 1 (each within the scatter of the next); then compound 3.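

Within the data shown here, on the naphthalen-2-yl compounds, this is the first direct reading of the bromine on its own in this assay: placing bromo instead of hydrogen on the six-membered aromatic ring, meta to a fused ring and para to a fused ring, gives a large gain in growth inhibition (a 140-fold lower number from compound 3 to compound 4 (2.15 log units; beyond the scatter)). With the bromine kept in place, changing the group on the carbon with a double bond to nitrogen moves the number far less, since naphthalen-2-yl in place of 4-methoxyphenyl gives a modest step (a 2.2-fold lower number from compound 2 to compound 4 (0.33 log units; beyond the scatter)), as does naphthalen-2-yl in place of phenyl (a 2.9-fold lower number from compound 1 to compound 4 (0.46 log units; beyond the scatter)), although both lie beyond the scatter. Among these compounds, then, the single bromine atom produces a much larger step than either aromatic group exchange, but nothing available explains why.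

Going by these compounds, whether the large step is specific to bromine remains open, as a chlorine, a methoxy or an amine at this position could give a different result. On these data alone, the bromine step has also been read only with naphthalen-2-yl present, so its size alongside the phenyl of compound 1 or the 4-methoxyphenyl of compound 2 is unknown.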